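The compounds below may be only part of what the source reports. "The series", "measured", "known", "first", "only" and "open" are said of these compounds alone.

In a functional assay on KB cells (Homo sapiens) for cytotoxicity (a higher number here means a weaker inhibitor, a lower number a stronger inhibitor), compound 1 `Cc1ccc(S(=O)(=O)Oc2ccc3c(c2)C(=O)C=CC3=O)cc1` gives 16400 nM and compound 2 `CS(=O)(=O)Oc1ccc2c(c1)C(=O)C=CC2=O` gives 11600 nM. For the measured compounds named here, these are the only two numbers so far, and compound 2 cannot be told apart from compound 1 on them. Going by the values given here, the one measured step, a 1.4-fold lower number from compound 1 to compound 2 (0.15 log units; within the scatter), puts methyl in place of 4-methylphenyl on a sulfonyl sulfur. Compound 3 `O=C1C=CC(=O)c2cc(Oc3cccs3)ccc21` carries a larger change, with thiophen-2-yl in place of methylsulfonyl on an oxygen on an aromatic ring. The measured step bears on this only loosely. It altered what sits on the sulfur, whereas here the whole methylsulfonyl leaves. Among the compounds with values here, no measured compound carries thiophen-2-yl, and the data give no firm direction for the change. Within the data shown here, with a 1.4-fold lower number from compound 1 to compound 2 (0.15 log units; within the scatter) as the only guide, no step beyond the scatter is expected in this assay, although the uncertainty remains wide. The expected step is a 1.3-fold lower number from compound 2 to compound 3 (0.11 log units; within the scatter). For compound 3 the estimated value is 9000 nM, with an expected range from 2500 nM to 28000 nM.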

Compound 3, half-maximal inhibitory concentration: 18300 nM
Compound 3: middle estimate off by 2.0-fold (0.31 log units), on the low side; measured number inside the range.
By their numbers in this assay, from the lowest: compounds 2, 1 and 3 (each within the scatter of the next).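

For the compounds shown here, compound 3 is the first compound here in which the methylsulfonyl group leaves altogether, and in this assay the result is a 1.6-fold higher number from compound 2 to compound 3 (0.20 log units; within the scatter). The earlier step changed only what sits on the sulfur, whereas this one shows that a number of this size does not depend on keeping a sulfonyl at this oxygen on an aromatic ring, since thiophen-2-yl, with its five-membered aromatic ring, cannot be told apart from methylsulfonyl here. Nothing available gives a reason for this outcome, so the comparison stands as an observation about these two compounds alone.

As far as these compounds go, whether an amine, a carboxylic acid or a longer alkyl chain on this oxygen would produce a step beyond the scatter remains open, and one thiophen-2-yl example cannot show how other aromatic rings would behave here. From the compounds shown here alone, it is also open whether the linking oxygen itself matters, as all three compounds keep it along with the shared core, so the effect of replacing either one cannot be judged from them.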